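Methyl to hydrogen on a ring oxygen, repeated

The source may report more compounds than this note shows. Statements on the series, on what has been measured and on what is new or still open speak of the compounds shown alone.

Compound 1 `COc1cc(OC)c(C(=O)/C=C/c2ccccc2OC)c(OC)c1`, compound 2 `COc1cccc(/C=C/C(=O)c2c(OC)cc(OC)cc2OC)c1` and compound 3 `COc1cc(O)c(C(=O)/C=C/c2ccccc2OC)c(OC)c1` have been measured in a functional assay on RL cells (Homo sapiens) for cytotoxicity, with a stated time of 48 h; a higher number here means a weaker inhibitor, a lower number a stronger inhibitor; compound 4 `COc1cccc(/C=C/C(=O)c2c(O)cc(OC)cc2OC)c1` has not. In this assay compound 1 gives 9000 nM, compound 2 gives 5900 nM and compound 3 gives 10100 nM. All three numbers lie within the usual scatter of one another, so no order among them is asserted.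

The cores of compound 1 and compound 2 differ as 3-methoxyphenyl in place of 2-methoxyphenyl on a double-bonded chain carbon bound to a double-bonded chain carbon, a change that made a 1.5-fold lower number from compound 1 to compound 2 (0.18 log units; within the scatter).

The change of interest is hydrogen in place of methyl on an oxygen on an aromatic ring, which from compound 1 to compound 3 made a 1.1-fold higher number from compound 1 to compound 3 (0.05 log units; within the scatter). The same change, at the same place, separates compound 2 from compound 4: hydrogen in place of methyl on an oxygen on an aromatic ring.

Going by the values given here, the one earlier instance, from compound 1 to compound 3, left the number essentially unchanged, a 1.1-fold higher number from compound 1 to compound 3 (0.05 log units; within the scatter). The step from compound 2 to compound 4 is expected to be of similar size, a 1.1-fold higher number from compound 2 to compound 4 (0.04 log units; within the scatter). Compound 4 is therefore estimated at 6500 nM in this assay, with a plausible range from 3500 nM to 12000 nM. This rests on a single prior instance of the change and should be read accordingly.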

Compound 4, half-maximal inhibitory concentration: 9000 nM
For compound 4 the middle estimate is 1.4-fold (0.14 log units) below the measured one; the measured number falls inside the stated range.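

In this assay, methoxy to hydroxy on an oxygen on an aromatic ring gives a 1.5-fold higher number from compound 2 to compound 4 (0.18 log units; within the scatter), so on this core too the step stays within the scatter. Set beside the earlier instance, the change carries from one core to the other with no detectable difference in size: the same change on two cores in this assay, a 1.1-fold higher number (0.05 log units; within the scatter) from compound 1 to compound 3 and a 1.5-fold higher number (0.18 log units; within the scatter) from compound 2 to compound 4, 1.4-fold (0.13 log units) apart, within the scatter of two such steps. Going by these compounds alone, this shows only that the exchange left the number within the scatter on these two cores in this one assay; since both steps lie within the scatter, neither a direction nor a size can be assigned to the change, and two instances do not establish how it behaves on other cores.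

Still open, going by these compounds, is whether a longer chain on that oxygen, or an amine or a carboxylic acid in place of the methoxy group, would move the number beyond the scatter. Also open, on these data alone, is whether any replacement at this place could separate the compounds at all, given that all the numbers so far sit close together.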